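Benzylsulfanyl in Place of Benzylamino: Expecting Compound 4

The compounds below may be only part of what the source reports. "The series", "measured", "known", "first", "only" and "open" are said of these compounds alone.

Compound 1 `CC(C)CSc1nc(N)nc2c1ncn2/C=C1/CC1(CO)CO` has "not determined" (no result reported) in an ADME assay on MOLT-3 cells (Homo sapiens) for cytotoxicity, with a stated time of 7 days; on this read-out lower numbers stand for higher toxicity in this test and higher numbers for lower toxicity in this test. Compound 2 `Nc1nc(NCc2ccccc2)c2ncn(/C=C3/CC3(CO)CO)c2n1` gives only a limit in this assay, > 20000 nM. Compound 3 `CCCCCCOc1nc(N)nc2c1ncn2/C=C1/CC1(CO)CO` likewise gives only a limit in this assay, > 20000 nM.

Compound 2 therefore stands at a limit of this assay rather than at a number, and the other two entries are a further limit and an entry without a single number. Among the compounds with values here, the one comparable step, a step that the two limits leave unreadable from compound 2 to compound 3, cannot be read for size, because the limit of > 20000 nM in this assay, at which 2 of the 3 values shown sit, holds both ends of it. Compound 4 `Nc1nc(SCc2ccccc2)c2ncn(/C=C3/CC3(CO)CO)c2n1` differs from compound 2 in one place: benzylsulfanyl in place of benzylamino on an aromatic carbon. The benzyl group stays, only the atom linking it to the aromatic carbon is exchanged. Within the data shown here, no measured step gives a readable size for such a change, so nothing in the numbers argues for a step beyond the scatter in either direction. The expected step is a step that the limit leaves unreadable from compound 2 to compound 4, which is essentially none, and the most likely outcome is that the assay again reports only its limit. Compound 4 is accordingly expected near 30000 nM, within a range from 10000 nM to 100000 nM.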

Compound 4, half-maximal cytotoxic concentration: > 20000 nM
Compound 4 ended at the assay's limit; the forecaster's own chance of this, stated with the estimate: 80%; the middle value lies beyond the limit too.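

Within the data shown here, no step among compound 2, compound 3 and compound 4 can be read for size in this assay, because all three stand at one and the same limit: the limit of > 20000 nM in this assay, at which 3 of the 4 values shown sit. The compounds shown leave open whether exchanging benzylamino, hexyloxy and benzylsulfanyl changes the read-out at all, and where compound 1 stands in this assay.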